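The compounds below may be only part of what the source reports. "The series", "measured", "known", "first", "only" and "open" are said of these compounds alone.

Among the measured compounds shown here, compound 3 `Cc1nc(N2CCC(N3CCNC3=O)CC2)nc2ccc(NC(=O)/C=C/c3ccc(OC(F)(F)F)cc3)cc12` gives 89% in an ADME assay on microsomes from liver (Mus musculus) for metabolic stability, with a stated time of 30 min (on this read-out higher numbers stand for a more stable compound and lower numbers for a less stable compound), the highest of the three numbers so far; compound 2 `COCC(=O)NC1CCN(c2nc(C)c3cc(NC(=O)/C=C/c4ccc(OC(F)(F)F)cc4)ccc3n2)CC1` gives 57% and compound 1 `Cc1nc(NCCNC(=O)C2CC2)nc2ccc(NC(=O)/C=C/c3ccc(OC(F)(F)F)cc3)cc12` gives 38% in this assay. Compound 4 `Cc1nc(N2CCC(N3C(=O)CCC3=O)CC2)nc2ccc(NC(=O)/C=C/c3ccc(OC(F)(F)F)cc3)cc12` differs from compound 3 by 2,5-dioxopyrrolidin-1-yl in place of 2-oxoimidazolidin-1-yl on a saturated ring carbon. The step that bears most closely on this is a number 32 percentage points higher from compound 2 to compound 3 (beyond the scatter), which also changed the group on the same saturated ring carbon; the other two steps, a number 19 percentage points higher from compound 1 to compound 2 (beyond the scatter) and a number 51 percentage points higher from compound 1 to compound 3 (beyond the scatter), changed the whole substituent on the aromatic carbon and bear less. The entering group has not been tried anywhere in the series, so the direction is not fixed by the data. A modest step downward, a number 19 percentage points lower from compound 3 to compound 4 (beyond the scatter), is expected for compound 4. Compound 4 is therefore estimated at 70% in this assay, with a range from 45% to 92%.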

Compound 4, percent of the compound remaining: 40%
Compound 4: the middle estimate sits 30 percentage points above what was measured; measured number below the stated range.
By their numbers in this assay, from the lowest: compounds 1 and 4 (each within the scatter of the next); then compound 2; then compound 3.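

Two five-membered rings on this saturated ring carbon are not interchangeable in this assay and replacing 2-oxoimidazolidin-1-yl with 2,5-dioxopyrrolidin-1-yl gives a number 49 percentage points lower from compound 3 to compound 4 (beyond the scatter) at this position. The entering ring also does not match the open-chain ((methoxymethyl)carbonyl)amino group, with a number 17 percentage points lower from compound 2 to compound 4 (beyond the scatter) on the same carbon. No measurement shown accounts for either step.

Still open, going by these compounds, is whether 2-oxopyrrolidin-1-yl, with a single ring carbonyl and no ring nitrogen-bound hydrogen, would read closer to compound 3 or to compound 4. A 2-oxooxazolidin-3-yl ring on this carbon would pose the same question.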